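The source may report more compounds than this note shows. Statements on the series, on what has been measured and on what is new or still open speak of the compounds shown alone.

Compound 1, `CC[C@H](CCn1cncn1)c1ccccc1`: 99.8 ug/mL
Compound 2, `CC[C@H](CCn1cncn1)c1ccc(F)cc1`: 110 ug/mL
Compound 3, `CC[C@H](CCn1cncn1)c1ccc(OC)cc1`: 118 ug/mL

All three compounds were tested in an ADME assay on RD cells (Homo sapiens) for cytotoxicity, read by MTT assay, with a stated time of 3 days; on this read-out higher numbers stand for lower toxicity in this test and lower numbers for higher toxicity in this test. Among them compound 1 sits within the scatter of the other two: the step of a 1.1-fold higher number from compound 1 to compound 2 (0.04 log units; within the scatter) and the step of a 1.2-fold higher number from compound 1 to compound 3 (0.07 log units; within the scatter) are both too small to count as a change, and the same holds for a 1.1-fold higher number from compound 2 to compound 3 (0.03 log units; within the scatter). The three numbers therefore describe one level of toxicity, not a trend.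

Compound 4, `c1ccc([C@@H](CCn2cncn2)C2CCCCC2)cc1`, has not yet been measured in this assay. Its structure differs from compound 1 in one place: cyclohexyl in place of ethyl on a saturated chain carbon bound to an aromatic carbon and a saturated chain carbon. For the measured compounds named here, none of the measured steps touches this part of the molecule; every step so far changed a substituent on the aromatic ring, and each stayed within the scatter. Going by the values given here, there is thus no measured step that bears directly on the exchange of ethyl for cyclohexyl, and the expectation rests only on how steady the numbers have been. Compound 4 is expected to give about 80 ug/mL, with a range from 35 ug/mL to 160 ug/mL. This amounts to an expected step of a 1.2-fold lower number from compound 1 to compound 4 (0.10 log units; within the scatter), which would not go beyond the scatter of this kind of measurement.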

Compound 4, half-maximal cytotoxic concentration: 9.2 ug/mL
Beside the measured number, compound 4's estimate is 8.7-fold (0.94 log units) above it; measured number below the stated range.
By their numbers in this assay, from the lowest: compound 4; then compounds 1, 2 and 3 (each within the scatter of the next).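

The saturated chain carbon bound to an aromatic carbon and a saturated chain carbon is a place where this assay responds strongly: cyclohexyl in place of ethyl gives an 11-fold lower number from compound 1 to compound 4 (1.04 log units; beyond the scatter), a step beyond the scatter that points to higher toxicity in this test. The exchanges on the aromatic ring among compound 1, compound 2 and compound 3 left the number at one level, so the set now holds a change that clearly moves it, and that change adds carbon atoms and a ring without adding any hydrogen-bond donor, hydrogen-bond acceptor or net charge. No measurement shown here accounts for the drop in the number.

Going by these compounds, what remains open is whether the ring itself or simply the greater number of carbon atoms matters, which a longer chain such as n-butyl or a smaller ring such as cyclopropyl at the same place could help to separate. On these data alone, it is also open whether an amine or a carboxylic acid on that group would change the number, and whether fluoro or methoxy on the aromatic ring would still make no difference with cyclohexyl in place.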